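Pyrazolopyrimidinone series: nitro to methoxy step on two cores

The compounds below may be only part of what the source reports. "The series", "measured", "known", "first", "only" and "open" are said of these compounds alone.

Measured so far:
compound 1 `O=C(Nn1c(-c2cccc([N+](=O)[O-])c2)nc2c(-c3ccc(Cl)cc3)n[nH]c2c1=O)c1ccccc1` — 87.8%
compound 2 `COc1cccc(-c2nc3c(-c4ccc(Cl)cc4)n[nH]c3c(=O)n2NC(=O)c2ccccc2)c1` — 87.3%
compound 3 `O=C(Nn1c(-c2cccc([N+](=O)[O-])c2)nc2c(-c3ccco3)n[nH]c2c1=O)c1ccccc1` — 21.2%

In a functional assay on HT-29 cells (Homo sapiens) for cytotoxicity, read by sulforhodamine B assay, with a stated time of 2 days, tested at 100 uM (a lower number here means less inhibition, a higher number more inhibition at the concentration tested (going by the name of the read-out)), compound 1 gives 87.8% and compound 2 gives 87.3%. The change between them is methoxy in place of nitro on an aromatic carbon, and it made a step of a number 0.5 percentage points lower from compound 1 to compound 2 (within the scatter). Compound 3 carries a different core; the two cores differ by furan-2-yl in place of 4-chlorophenyl on an aromatic carbon, and that change made a step of a number 66.6 percentage points lower from compound 1 to compound 3 (beyond the scatter), leaving compound 3 at 21.2%.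

Compound 4 `COc1cccc(-c2nc3c(-c4ccco4)n[nH]c3c(=O)n2NC(=O)c2ccccc2)c1` is not yet measured. It differs from compound 3 by methoxy in place of nitro on an aromatic carbon, the same change as from compound 1 to compound 2, at the same place. Because the earlier instance gave a number 0.5 percentage points lower from compound 1 to compound 2 (within the scatter), compound 4 is expected to stay close to compound 3: an estimated step of a number 0.2 percentage points lower from compound 3 to compound 4 (within the scatter) in this assay. Compound 4 is thus estimated at 21%, between 8% and 38%.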

Compound 4, a percentage reported as inhibition, at one concentration (the size of the read-out at that concentration, not a potency): 49.8%
Compound 4: the middle estimate sits 28.8 percentage points below what was measured; measured number outside the range, above it.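

In this assay, methoxy in place of nitro gives a number 28.6 percentage points higher from compound 3 to compound 4 (beyond the scatter), so the change does not carry over unaltered from the core of compound 1 to the core of compound 3: the same change on two cores in this assay, a number 0.5 percentage points lower (within the scatter) from compound 1 to compound 2 and a number 28.6 percentage points higher (beyond the scatter) from compound 3 to compound 4, 29.1 percentage points apart, beyond the scatter of two such steps

Furan-2-yl in place of 4-chlorophenyl gives a number 37.5 percentage points lower from compound 2 to compound 4 (beyond the scatter), the same direction as with nitro but a different size: the same change on two cores in this assay, a number 66.6 percentage points lower (beyond the scatter) from compound 1 to compound 3 and a number 37.5 percentage points lower (beyond the scatter) from compound 2 to compound 4, 29.1 percentage points apart, beyond the scatter of two such steps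

These four compounds show that the two changes do not add independently here, but they do not show why, or how either change would behave on any other core.

Open, as far as these compounds go, is whether an amine or a carboxylic acid at this place would follow the methoxy or the nitro result. Also open, from the compounds shown here alone, is whether a thiophene in place of furan-2-yl would show the same dependence.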